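The compounds below may be only part of what the source reports. "The series", "measured", "known", "first", "only" and "open" are said of these compounds alone.

Compound 1 `COc1ccc(C(=O)/C(=C/C2CCCCC2)COC(C)=O)cc1`: in a functional assay on A549 cells (Homo sapiens) for inhibition, read by XTT assay, with a stated time of 48 h (on this read-out higher numbers stand for weaker inhibition and lower numbers for stronger inhibition), compound 1 gives 90000 nM.
Compound 2 `COc1ccc(C(=O)/C(=C/C2CCCCC2)CCOC(C)=O)cc1`: for compound 2 this assay reports only a limit, > 100000 nM.
Compound 3 `COc1ccc(C(=O)/C(=C/c2ccc(Cl)cc2)CCOC(C)=O)cc1`: in this assay compound 3 gives 86000 nM.

Compound 2 therefore stands at the limit of this assay rather than at a number, as recorded by the limit of > 100000 nM in this assay, at which 1 of the 3 values shown sits. The unmeasured compound 4 `COc1ccc(C(=O)/C(=C/C2CCCCC2)CC(C)OC(C)=O)cc1` differs from compound 2 in one place: methyl in place of hydrogen on a saturated chain carbon bound to an oxygen next to a carbonyl group and a saturated chain carbon. Going by the values given here, no measured step alters the same saturated chain carbon, so the two steps that touch compound 2 are the only guide. The step of an at least 1.1-fold higher number from compound 1 to compound 2 (0.04 log units; that floor lies within the scatter) and the step of an at least 1.1-fold lower number from compound 2 to compound 3 (0.06 log units; that floor lies within the scatter) both give only floors that lie within the scatter, and neither moves the read-out beyond it. Compound 4 is therefore expected to show no step beyond the scatter, so that a number no higher from compound 2 to compound 4 (the limit leaves the size open) is the estimated change in this assay. Compound 4 is expected to sit at 100000 nM, within a range from 50000 nM to 200000 nM, and most likely this assay will again report only a limit for it.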

Compound 4, half-maximal inhibitory concentration: 98000 nM
Estimate against measurement, compound 4: 1.0-fold (0.01 log units) above; measured number inside the range.
By their numbers in this assay, from the lowest: compounds 3, 1 and 4 (each within the scatter of the next). At a limit, above all of these: compound 2.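

Methyl in place of hydrogen on this saturated chain carbon bound to an oxygen next to a carbonyl group and a saturated chain carbon gives compound 4 a number in this assay, yet the change itself can be read only as a floor, an at least 1.0-fold lower number from compound 2 to compound 4 (0.00 log units; that floor lies within the scatter). Its true size stays unknown, as compound 2 is recorded only at a limit: the limit of > 100000 nM in this assay, at which 1 of the 4 values shown sits.

Going by these compounds alone, the one full comparison is a 1.1-fold higher number from compound 1 to compound 4 (0.04 log units; within the scatter), so 1-acetoxyethyl in place of acetoxy leaves the read-out within the scatter of compound 1.

From the compounds shown here alone, whether any group on this carbon can move the read-out beyond the scatter stays open, as compound 2 and compound 4 carry only hydrogen and methyl there. An ethyl group, a hydroxyl or an amine on this carbon is not among the compounds shown, nor is 4-chlorophenyl combined with the methyl.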